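The source may hold more compounds than are shown below. What is called first, only, known or untested is meant among the compounds shown, and "the series" means these compounds.

Measured compounds:
compound 1, `Cc1ccc(NC(=S)NC(=O)c2ccc(OCc3cccc(Cl)c3Cl)cc2)cc1-c1nc2ccccc2[nH]1`: > 100000 nM
compound 2, `Cc1ccc(COc2ccc(C(=O)NC(=S)Nc3ccc(C)c(-c4nc5ccccc5[nH]4)c3)cc2)cc1`: 4980 nM
compound 3, `Cc1ccc(NC(=O)NC(=O)c2ccc(OCc3cccc(Cl)c3Cl)cc2)cc1-c1nc2ccccc2[nH]1`: > 100000 nM

In a functional assay on MGC-803 cells (Homo sapiens) for inhibition, read by MTT assay, with a stated time of 48 h (a higher number here means a weaker inhibitor, a lower number a stronger inhibitor), compound 1 gives only a limit, > 100000 nM. Compound 3 likewise gives only a limit, > 100000 nM. Compound 2 gives a number, 4980 nM. Going by these compounds, the change 4-methylphenyl in place of 2,3-dichlorophenyl on a saturated chain carbon bound to an oxygen on an aromatic ring produces an at least 20-fold lower number from compound 1 to compound 2 (1.30 log units; beyond the scatter); the step starts from the limit of > 100000 nM in this assay, at which 2 of the 3 values shown sit, so its full size stays open. The difference between the cores of compound 1 and compound 3 is not broken down here. Compound 4, `Cc1ccc(COc2ccc(C(=O)NC(=O)Nc3ccc(C)c(-c4nc5ccccc5[nH]4)c3)cc2)cc1`, is not yet measured; it relates to compound 3 by 4-methylphenyl in place of 2,3-dichlorophenyl on a saturated chain carbon bound to an oxygen on an aromatic ring, the same change at the same place. The expected step is an at least 10-fold lower number from compound 3 to compound 4 (1.00 log units; beyond the scatter), read as a move down from a limit. This expectation rests on compound 1 and compound 2 and an at least 20-fold lower number from compound 1 to compound 2 (1.30 log units; beyond the scatter). Compound 4 is expected at 10000 nM in this assay, between 3000 nM and 60000 nM.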

Compound 4, half-maximal inhibitory concentration: 4250 nM
The estimate for compound 4 lay 2.4-fold (0.37 log units) above the measured number, and the stated range covers the measured number.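

In this assay, 4-methylphenyl in place of 2,3-dichlorophenyl gives an at least 23-fold lower number from compound 3 to compound 4 (1.37 log units; beyond the scatter), so the change points the same way on both cores shown: the same change on two cores in this assay, an at least 20-fold lower number (1.30 log units; beyond the scatter) from compound 1 to compound 2 and an at least 23-fold lower number (1.37 log units; beyond the scatter) from compound 3 to compound 4; the limit leaves it open whether they differ

The full size of each step stays open, since each starts from a limit: the limit of > 100000 nM in this assay, at which 2 of the 4 values shown sit.

Two cores do not show that the change would carry over to any other core in the series.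

The compounds shown leave open whether the lower numbers follow from the entering methyl or from the loss of the two chlorines. Plain phenyl, 4-chlorophenyl or 3-chlorophenyl on the same saturated chain carbon would separate these two readings.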